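The source may report more compounds than this note shows. Statements on the series, on what has been measured and on what is new or still open speak of the compounds shown alone.

In a functional assay on U-373MG ATCC cells for cytotoxicity against U373 MG (Homo sapiens), read by colorimetric assay and MTT assay (a lower number here means a stronger inhibitor, a higher number a weaker inhibitor), compound 1 (`COc1cc(OC)c2cc(-c3ccc(OCc4ccccc4)cc3)c(O)nc2c1`) gives 10000 nM. Compound 2 (`COc1ccc(-c2cc3c(OC)cc(OC)cc3n(CC(=O)OCc3ccccc3)c2=O)cc1`) gives 10000 nM in this assay, which places compound 2 level with compound 1, within the usual scatter of such measurements. Within the data shown here, these two readings are all that is known so far, and the two structures do not differ in one place only, so no measured step shows what a single change does.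

Compound 3 (`CCN(CC)C(=O)CCn1c(=O)c(-c2ccc(OC)cc2)cc2c(OC)cc(OC)cc21`) is reached from compound 2 by one structural change: (diethylcarbamoyl)methyl in place of benzyloxycarbonyl on a saturated chain carbon bound to an aromatic nitrogen. Here (diethylcarbamoyl)methyl stands in place of benzyloxycarbonyl on a saturated chain carbon bound to an aromatic nitrogen.

Since compound 1 reads 10000 nM and compound 2 reads 10000 nM, there is no measured basis for expecting a move in either direction, and no change beyond the scatter is expected in this assay. The estimated change is no change at the digits printed from compound 2 to compound 3 (within the scatter). The estimate for compound 3 is 10000 nM, with the result expected to fall between 4000 nM and 25000 nM.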

Compound 3, half-maximal inhibitory concentration: 10000 nM
Estimate against measurement, compound 3: no gap at the digits printed, within the range that was stated.
By their numbers in this assay, from the lowest: compounds 1, 2 and 3 (each within the scatter of the next).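

In this assay, putting (diethylcarbamoyl)methyl in place of benzyloxycarbonyl on a saturated chain carbon bound to an aromatic nitrogen gives no change at the digits printed from compound 2 to compound 3 (within the scatter). Among these compounds, this is the first single change measured, and it shows that this place tolerates the loss of the six-membered aromatic ring of carbon only and the entry of a nitrogen without any shift in the reading. No further data bear on this result.

The compounds shown leave open whether any group at this place can move the reading at all, for example a carboxylic acid or a tertiary amine at the end of the chain, or a longer chain than 2-(diethylcarbamoyl)ethyl. They also leave open whether a change elsewhere on the shared core, such as a hydroxyl in place of a methoxy group, would shift the reading in this assay.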